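Side-chain change from compound 2 to compound 3

A few compounds are considered here, and "the series" means these few. Any claim that something is new, unique, unknown or untested is made for them only; others in the source may bear on it.

In a functional assay on HCT-116 cells (Homo sapiens) for antiproliferative activity, read by MTT assay, with a stated time of 48 h (on this read-out higher numbers stand for weaker inhibition and lower numbers for stronger inhibition), compound 1 `Cc1c(C(=O)NCCCN(C)C)oc2ccc(N(Cc3ccc(Br)cc3)S(=O)(=O)c3ccc(Br)cc3)cc12` gives 3070 nM. Compound 2 `Cc1c(C(=O)NCCS(C)(=O)=O)oc2ccc(N(Cc3ccc(Br)cc3)S(=O)(=O)c3ccc(Br)cc3)cc12` reads > 40000 nM, which is a limit of the assay and not a number. Compound 3 `Cc1c(C(=O)NCC(O)CO)oc2ccc(N(Cc3ccc(Br)cc3)S(=O)(=O)c3ccc(Br)cc3)cc12` is the next to be read, and its change from compound 2 is 1,2-dihydroxyethyl in place of (methylsulfonyl)methyl on a saturated chain carbon bound to an amide-type nitrogen. Going by the values given here, one measured step bears on this: an at least 13-fold higher number from compound 1 to compound 2 (1.11 log units; beyond the scatter), a large step beyond the scatter, with methylsulfonyl in place of (dimethylamino)methyl. The new change does not bring (dimethylamino)methyl back, and both the leaving and the entering group carry no net charge. Compound 3 is therefore expected to stay with compound 2, with no step beyond the scatter in this assay, and a report as a limit only is quite possible. The expected step is an at least 1.1-fold lower number from compound 2 to compound 3 (0.05 log units; that floor lies within the scatter). For compound 3 the estimated value is 35000 nM, with an expected range from 12000 nM to 80000 nM.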

Compound 3, half-maximal inhibitory concentration: 27800 nM
Compound 3: the middle estimate sits 1.3-fold (0.10 log units) above what was measured; the measured number falls inside the stated range.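

In this assay, the side-chain exchange gives an at least 1.4-fold lower number from compound 2 to compound 3 (0.15 log units; that floor lies within the scatter). Compound 2 is known only as a limit of the assay, so the true size of this step stays unknown, and its printed floor does not separate the two side chains: the limit of > 40000 nM in this assay, at which 1 of the 3 values shown sits.

The new information lies in a 9.1-fold higher number from compound 1 to compound 3 (0.96 log units; beyond the scatter). Two different side chains without the dimethylamino group, in compound 2 and compound 3, both read on the weaker side of compound 1, so the loss seen in the first step is not tied to the methylsulfonyl group alone.

Going by these compounds, whether a primary amine at the chain end would read like compound 1 or like compound 3 stays open. The same holds for a carboxylic acid in that place, and for a longer chain carrying the dimethylamino group.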